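Methyl ester of the acid in the growth assay

The source may hold more compounds than are shown below. What is called first, only, known or untested is meant among the compounds shown, and "the series" means these compounds.

Measured in a functional assay on MDA-MB-231 cells (Homo sapiens) for inhibition, read by sulforhodamine B assay, with a stated time of 72 h; a lower number here means a stronger inhibitor of growth, a higher number a weaker inhibitor of growth:
- compound 1 `CN1CCN(C(=O)/C=C/c2ccncc2-c2ccc3ccccc3c2)CC1`: > 10000 nM, a limit
- compound 2 `O=C(O)/C=C/c1ccncc1-c1ccc2ccccc2c1`: > 10000 nM, a limit

Compound 2 has no number, only the limit > 10000 nM. Compound 1 is also known only by a limit. The whole reading so far is the limit of > 10000 nM in this assay, at which 2 of the 2 values shown sit.

Compound 3 `COC(=O)/C=C/c1ccncc1-c1ccc2ccccc2c1` is the next to be read. It differs from compound 2 by methyl in place of hydrogen on an oxygen next to a carbonyl group, so that carboxy becomes methoxycarbonyl.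

For the measured compounds named here, the only measured step at this carbonyl is a step that the two limits leave unreadable from compound 1 to compound 2. With no readable size, it offers neither a magnitude nor a direction to carry over. No shift beyond the scatter is therefore expected in this assay, and a further limit is the likelier report for compound 3.

The expected change is a step that the limit leaves unreadable from compound 2 to compound 3, an estimate resting on limits alone. For compound 3 the estimated value is 12000 nM, with an expected range of 5000 nM to 30000 nM.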

Compound 3, concentration for 50% growth inhibition: 4710 nM
The estimate for compound 3 lay 2.5-fold (0.41 log units) above the measured number, outside the stated range (below it).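

In this assay, a number can now be read at this carbonyl, so the group on it does affect growth inhibition within the shared core: methyl in place of hydrogen on the oxygen next to the carbonyl group gives an at least 2.1-fold lower number from compound 2 to compound 3 (0.32 log units; beyond the scatter). Methoxy in place of 4-methylpiperazin-1-yl on the carbonyl carbon gives an at least 2.1-fold lower number from compound 1 to compound 3 (0.32 log units; beyond the scatter), so the methyl ester stands apart from both earlier compounds, whereas the step between those two cannot be read. Both new steps start from a limit, so they give a minimum size and not a true one, and the limit still holds most of the series: the limit of > 10000 nM in this assay, at which 2 of the 3 values shown sit.

As far as these compounds go, it remains open whether this shift is specific to methoxycarbonyl or extends to an ethyl ester, a longer chain on the oxygen, or a primary amide on the same carbonyl carbon. A single ester also leaves open how far the number can fall at this position, and whether a hydroxymethyl group in place of the whole methoxycarbonyl would keep any of the shift.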